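The compounds below may be only part of what the source reports. "The series", "measured", "known", "first", "only" and "open" are said of these compounds alone.

Compound 3 `COc1ccc(/C=C\c2cc(OC)c(OC)c(OC)c2)cc1OCc1ccc(CNCCO)cc1` gives 5900 nM in a functional assay on HepG2 cells (Homo sapiens) for antiproliferative activity, read by CCK-8 assay, with a stated time of 48 h; a lower number here means a stronger inhibitor, a higher number a weaker inhibitor. Among the three measured compounds its number is the second highest, although all three sit within the scatter of one another: compound 2 `COc1ccc(/C=C\c2cc(OC)c(OC)c(OC)c2)cc1OCc1ccc(CN2CC[C@@H](O)C2)cc1` gives 6200 nM, and compound 1 `COc1ccc(/C=C\c2cc(OC)c(OC)c(OC)c2)cc1OCc1ccc(CN2CCCCC2C(=O)O)cc1` gives 3100 nM; the steps of a 2.0-fold higher number from compound 1 to compound 2 (0.30 log units; within the scatter), a 1.9-fold higher number from compound 1 to compound 3 (0.28 log units; within the scatter) and a 1.1-fold lower number from compound 2 to compound 3 (0.02 log units; within the scatter) are each within the scatter. Compound 4 `COc1ccc(/C=C\c2cc(OC)c(OC)c(OC)c2)cc1OCc1ccc(CNCCN(C)C)cc1` carries the change (dimethylamino in place of hydroxy on a saturated chain carbon, two bonds along the chain from an amine nitrogen). Every measured step alters the group on the saturated chain carbon bound to an aromatic carbon, and none moved the number beyond the scatter, so for compound 4 no step beyond the scatter is expected in this assay. The expected step is a 1.1-fold lower number from compound 3 to compound 4 (0.03 log units; within the scatter). Compound 4 is therefore estimated at 5500 nM, between 2500 nM and 12000 nM.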

Compound 4, half-maximal inhibitory concentration: 4400 nM
The estimate for compound 4 lay 1.3-fold (0.10 log units) above the measured number; the measured number falls inside the stated range.
By their numbers in this assay, from the lowest: compounds 1, 4, 3 and 2 (each within the scatter of the next).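

In this assay the swap of hydroxy for dimethylamino on a saturated chain carbon, two bonds along the chain from an amine nitrogen, stays within the scatter (a 1.3-fold lower number from compound 3 to compound 4 (0.13 log units; within the scatter)), so this outer end of the chain tolerates the loss of a hydrogen-bond donor and a larger group. The other two steps also stay within the scatter (a 1.4-fold lower number from compound 2 to compound 4 (0.15 log units; within the scatter); a 1.4-fold higher number from compound 1 to compound 4 (0.15 log units; within the scatter)), which extends the flat picture to a second amine nitrogen. No measurement offered here explains this result. Still open, as far as these compounds go, is whether a carboxylic acid at this chain end, or a longer chain carrying the dimethylamino, would move the number beyond the scatter.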